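The source may report more compounds than this note shows. Statements on the series, on what has been measured and on what is new or still open speak of the compounds shown alone.

Measured in an ADME assay on microsomes from liver (Homo sapiens) for metabolic stability, read by LC-MS, tested at 1 uM; a lower number here means slower removal, a higher number faster removal of the compound:

- Compound 1 `CC(C)(O)CNCCCOc1ccc([C@H]2CC[C@]3(CC2)OOC2(O3)C3CC4CC(C3)CC2C4)cc1`: 8 mL.min-1.g-1
- Compound 2 `c1cc([C@H]2CC[C@]3(CC2)OOC2(O3)C3CC4CC(C3)CC2C4)ccc1OCCC1CCNCC1`: < 7 mL.min-1.g-1
- Compound 3 `c1cc([C@H]2CC[C@]3(CC2)OOC2(O3)C3CC4CC(C3)CC2C4)ccc1OC1CCNCC1`: 15 mL.min-1.g-1

The entry for compound 2 is a limit of the assay and not a number. Compound 3 stands within the scatter of compound 1, as shown by a 1.9-fold higher number from compound 1 to compound 3 (0.27 log units; within the scatter). Its separation from compound 2 goes beyond the scatter, as shown by an at least 2.1-fold higher number from compound 2 to compound 3 (0.33 log units; beyond the scatter). Both steps exchange piperidin-4-yl for another group on an oxygen on an aromatic ring. Compound 4 `NCCS(=O)(=O)CCOc1ccc([C@H]2CC[C@]3(CC2)OOC2(O3)C3CC4CC(C3)CC2C4)cc1` differs from compound 3 at that same place: 2-((2-aminoethyl)sulfonyl)ethyl in place of piperidin-4-yl on an oxygen on an aromatic ring. The entering 2-((2-aminoethyl)sulfonyl)ethyl has not itself been measured, so these steps offer only a rough guide to size. Going by compound 1 at 8 mL.min-1.g-1, whose 3-((2-hydroxy-2-methylpropyl)amino)propyl also has no ring, a small move towards a lower number is expected in this assay, probably within the scatter. The expected change is a 1.7-fold lower number from compound 3 to compound 4 (0.22 log units; within the scatter). Compound 4 is estimated at 9 mL.min-1.g-1, with an expected range of 5 mL.min-1.g-1 to 18 mL.min-1.g-1.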

Compound 4, intrinsic clearance in microsomes: 9 mL.min-1.g-1
Compound 4: the middle estimate sits on the measured number at the digits printed; measured number inside the range.
By their numbers in this assay, from the lowest: compounds 1, 4 and 3 (each within the scatter of the next). At a limit, below all of these: compound 2.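

In this assay, 2-((2-aminoethyl)sulfonyl)ethyl, which has no ring, takes the place of piperidin-4-yl on an oxygen on an aromatic ring with a 1.7-fold lower number from compound 3 to compound 4 (0.22 log units; within the scatter), so at this position a ringless chain holding a sulfonyl cannot be told apart from the piperidine. The two ringless chains also cannot be told apart, with (2-aminoethyl)sulfonyl in place of ((2-hydroxy-2-methylpropyl)amino)methyl giving a 1.1-fold higher number from compound 1 to compound 4 (0.05 log units; within the scatter). Against compound 2, which sits at a limit of the assay and not at a number, the step reads only as a floor, an at least 1.2-fold higher number from compound 2 to compound 4 (0.10 log units; that floor lies within the scatter), and that limit is shared by no other compound shown: the limit of < 7 mL.min-1.g-1 in this assay, at which 1 of the 4 values shown sits.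

The compounds shown leave open whether the sulfonyl or the amine matters more in this chain. As far as these compounds go, what a plain carbon chain in place of the sulfonyl, or a carboxylic acid in place of the amine, would give in this assay remains unknown.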